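Chloro to Bromo: One Change Tried on a Second Core

The source may hold more compounds than are shown below. What is called first, only, known or untested is meant among the compounds shown, and "the series" means these compounds.

Measured so far:
- Compound 1, `O=C(/C=C/c1ccccc1)NS(=O)(=O)c1ccc(Cl)cc1`: in a functional assay on B16-F10 cells (Mus musculus) for antiproliferative activity, read by ELISA and MTT assay, with a stated time of 48 h (on this read-out lower numbers stand for stronger inhibition and higher numbers for weaker inhibition), compound 1 gives 2.2 ug/mL.
- Compound 2, `O=C(/C=C/c1ccccc1)NS(=O)(=O)c1ccc(Br)cc1`: in this assay compound 2 gives 3.9 ug/mL.
- Compound 3, `O=C(/C=C/c1ccc(Cl)cc1)NS(=O)(=O)c1ccccc1`: in this assay compound 3 gives 2.2 ug/mL.

Compound 1 and compound 2 share one core and differ in a single spot: bromo in place of chloro on an aromatic carbon. That change made a 1.8-fold higher number from compound 1 to compound 2 (0.25 log units; within the scatter), a step that the assay's own scatter could account for on its own. Compound 3 has the same atoms as compound 1 but joined differently; the difference between the two cores is not broken down here. What can be said of the pair is that the two values stand level at the digits recorded, both at the low end of the three numbers, so neither can be called stronger than the other.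

Compound 4, `O=C(/C=C/c1ccc(Br)cc1)NS(=O)(=O)c1ccccc1`, is not yet measured. It stands to compound 3 as compound 2 stands to compound 1: bromo in place of chloro on an aromatic carbon. Both place descriptions read the same word for word, so this is the same change made on a second core. Among the measured compounds shown here, the only guide is the one earlier instance, which lay within the scatter. On that basis the step from compound 3 to compound 4 in this assay is expected to be small and of similar size, a 1.6-fold higher number from compound 3 to compound 4 (0.20 log units; within the scatter), because compound 1 to compound 2 gave a 1.8-fold higher number from compound 1 to compound 2 (0.25 log units; within the scatter). Compound 4 is therefore estimated at 3.5 ug/mL, with a likely range from 1.8 ug/mL to 7 ug/mL.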

Compound 4, half-maximal inhibitory concentration: 3.9 ug/mL
Beside the measured number, compound 4's estimate is 1.1-fold (0.05 log units) below it; the measured number falls inside the stated range.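

In this assay, bromo in place of chloro on the second core gives a 1.8-fold higher number from compound 3 to compound 4 (0.25 log units; within the scatter), and this step sits close in size to the one seen earlier on the first core: (the same change on two cores in this assay, a 1.8-fold higher number (0.25 log units; within the scatter) from compound 1 to compound 2 and a 1.8-fold higher number (0.25 log units; within the scatter) from compound 3 to compound 4, 1.0-fold (0.00 log units) apart, within the scatter of two such steps). So on these two cores the change carried over with no difference that can be told apart, but each step is small enough that the assay's scatter could account for it on its own. This shows that the swap behaved alike in both places without showing that bromo and chloro truly differ in this assay, and two cores are too few to support a rule for other cores in the series.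

The compounds shown carry only chloro or bromo, para to a large group on a six-membered aromatic ring of carbon only, so it stays open what fluoro, methoxy, an amine or a carboxylic acid would do in that place. Also open, as far as these compounds go, is how a compound with no halogen at all, or with a halogen on both aromatic rings, would read in this assay and whether the same small step would appear there.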